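Ethoxy in Place of Fluoro on a Weakly Cytotoxic Scaffold

This account rests on a few compounds, and the source may have more. Where it says the series, first, only, none or still open, it means among the compounds named here.

Compound 3 `Fc1ccc(Nc2nc(SCc3ccc(C(F)(F)F)cc3)nc3ccccc23)cc1` is the only one of the three measured compounds to give a number in a functional assay on MCF7 cells (Homo sapiens) for cytotoxicity, read by MTT assay, with a stated time of 72 h; on this read-out lower numbers stand for stronger inhibition and higher numbers for weaker inhibition: compound 3 gives 36300 nM. Compound 1 `FC(F)(F)c1ccc(CSc2nc(Nc3ccccc3C(F)(F)F)c3ccccc3n2)cc1` sits at a limit of the assay, > 50000 nM. Compound 2 `FC(F)(F)c1ccc(CSc2nc(Nc3ccccc3Cl)c3ccccc3n2)cc1` also sits at a limit, > 50000 nM. Accordingly a step that the two limits leave unreadable from compound 1 to compound 2, while an at least 1.3-fold lower number from compound 1 to compound 3 (0.13 log units; that floor lies within the scatter) and an at least 1.3-fold lower number from compound 2 to compound 3 (0.13 log units; that floor lies within the scatter). Compound 4 `CCOc1ccc(Nc2nc(SCc3ccc(C(F)(F)F)cc3)nc3ccccc23)cc1` differs from compound 3 by ethoxy in place of fluoro on an aromatic carbon. No measured step touches that position, and the shown steps rest on (the limit of > 50000 nM in this assay, at which 2 of the 3 values shown sit), so any guide is weak. The writer therefore expects a 1.2-fold lower number from compound 3 to compound 4 (0.08 log units; within the scatter), and estimates for compound 4 a value of 30000 nM, between 9000 nM and 90000 nM.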

Compound 4, half-maximal inhibitory concentration: > 50000 nM
Compound 4: no number, only a limit (the forecaster's own chance of this, stated with the estimate: 35%); middle value at least 1.6-fold (0.22 log units) away from the limit.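

For the compounds shown here, the first measured change at this position, on a six-membered aromatic ring and para to a large group, gives in this assay an at least 1.3-fold higher number from compound 3 to compound 4 (0.13 log units; that floor lies within the scatter). Compound 4 reaches only a limit, > 50000 nM, so ethoxy in place of fluoro yields no number here. The steps from compound 1 and from compound 2 to compound 4 cannot be read because both ends of each are limits: the limit of > 50000 nM in this assay, at which 3 of the 4 values shown sit.

Going by these compounds, the true size of the step from fluoro to ethoxy stays open. So does whether an amine, a carboxylic acid or a longer chain at this position would give a number in this assay.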